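This account rests on a few compounds, and the source may have more. Where it says the series, first, only, none or still open, it means among the compounds named here.

Measured so far, values from a physicochemical assay for lipophilicity, read by HPLC, at pH 7.4 (a lower number here means a more polar compound, a higher number a more lipophilic compound), in the series:
- compound 1 (`Cc1ccccc1N1C(=O)/C(=C/c2ccc(O)c(Cl)c2)S/C1=N\CCO`) gives 1.9
- compound 2 (`CCC/N=C1\S/C(=C\c2ccc(O)c(Cl)c2)C(=O)N1C(C)C`) gives > 4.3
- compound 3 (`CCC/N=C1\S/C(=C\c2ccc(O)c(Br)c2)C(=O)N1c1ccccc1C`) gives 3.9

Compound 1 at 1.9 holds the lower of the two actual numbers. Compound 3 at 3.9 lies beyond the scatter from it. Compound 2 gives > 4.3 as a limit of the assay and not a number.

The next compound to be read is compound 4 (`Cc1ccccc1N1C(=O)/C(=C/c2ccc(O)c(Cl)c2)S/C1=N\C1COC1`), and the change from compound 1 is oxetan-3-yl in place of 2-hydroxyethyl on a double-bonded nitrogen. For the measured compounds named here, no measured pair isolates this change. Going by the values given here, compound 1 and compound 3 differ in more than one place, so compound 3 at 3.9 sets no size for the step. With the hydrogen-bond donor gone, a modest upward move is expected in this assay and is estimated as a number 0.50 log units higher from compound 1 to compound 4 (beyond the scatter) on this basis. For compound 4 the estimate is 2.4 with an expected range from 1.9 to 3 in this reading.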

Compound 4, distribution coefficient: 2.6
Compound 4: middle estimate off by 0.20 log units, on the low side, within the range that was stated.
By their numbers in this assay, from the lowest: compound 1; then compound 4; then compound 3. At a limit, above all of these: compound 2.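

For the compounds shown here, the reading in this assay moves a number 0.70 log units higher from compound 1 to compound 4 (beyond the scatter) when oxetan-3-yl replaces 2-hydroxyethyl on a double-bonded nitrogen, the first change that can be read at one place alone. This shows that the reading responds to a change at this position while the rest of compound 1 stays fixed. Several things change together in this one step, as a hydrogen-bond donor leaves and a four-membered ring enters, and nothing measured here separates them or gives a cause.

Going by these compounds alone, compound 2 and compound 3 differ from compound 1 in more than one place, so they add no second step at this position. On these data alone, how a morpholine, an amine, a carboxylic acid or a longer chain on this nitrogen would read in this assay remains open.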